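This account rests on a few compounds, and the source may have more. Where it says the series, first, only, none or still open, it means among the compounds named here.

Working notes on the series. Every measured member so far sits at the ceiling of a functional assay on QGY7701 cells (Homo sapiens) for cytotoxicity, read by MTT assay, with a stated time of 24 h; on this read-out higher numbers stand for weaker inhibition and lower numbers for stronger inhibition. Compound 1, `C=CC1=C(C(=O)NCCCCC)C(c2ccc(Cl)c(Cl)c2)OC1`, is reported in this assay only as a limit, > 100000 nM. Compound 2, `C=CC1=C(C(=O)O)C(c2ccc(OC)cc2)OC1`, likewise returns only a limit, > 100000 nM. Compound 3, `C=CC1=C(C(=O)Nc2ccccc2OC)C(c2ccc(OC)cc2)OC1`, also gives only a limit, > 100000 nM. Across the set the picture is the limit of > 100000 nM in this assay, at which 3 of the 3 values shown sit. Among the compounds with values here, no two measured compounds differ in a single place, so no step size has been measured, and the three numbers give no order among the compounds.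

Compound 4, `C=CC1=C(C(=O)NCc2ccccc2)C(c2ccc(Cl)c(Cl)c2)OC1`, is the next member to be run. Relative to compound 1 it carries phenyl in place of butyl on a saturated chain carbon bound to an amide-type nitrogen. Within the data shown here, no measured step is available to anchor the change, so the step expected from compound 1 to compound 4 is a step that the limit leaves unreadable from compound 1 to compound 4, which is none beyond the scatter of this assay, and another limit is the most probable report. Compound 4 is estimated at 120000 nM, with a range from 40000 nM to 400000 nM.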

Compound 4, half-maximal inhibitory concentration: > 100000 nM
Compound 4: no number, only a limit (the forecaster's own chance of this, stated with the estimate: 80%); the middle value is on the limit's open side.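

Within the data shown here, compound 1 and compound 4 each return only a limit in this assay, so no step between them can be read. The compounds shown leave open whether any member has a readable value, and so any order among them, the series standing at: the limit of > 100000 nM in this assay, at which 4 of the 4 values shown sit.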